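Replacing a trichlorophenyl with a methoxyphenyl on a guanidine core

The source may report more compounds than this note shows. Statements on the series, on what has been measured and on what is new or still open speak of the compounds shown alone.

Measured compounds:
- compound 1, `NC1=NC2(CCSCC2)N(OCCCOc2cccc(Cl)c2)C(N)=N1`: 1 nM
- compound 2, `NC1=NC2(CCOCC2)N(OCCCOc2cc(Cl)c(Cl)cc2Cl)C(N)=N1`: 2750 nM
- compound 3, `NC1=NC2(CCSCC2)N(OCCCOc2ccc(Cl)cc2)C(N)=N1`: 10 nM

In a functional assay on HCT-116 cells (Homo sapiens) for antiproliferative activity, read by MTT assay, with a stated time of 72 h (on this read-out lower numbers stand for stronger inhibition and higher numbers for weaker inhibition), compound 2 gives the highest of the three numbers, far from compound 3 and further still from compound 1. Going by the values given here, the only single-point step among the measured compounds is a 10-fold higher number from compound 1 to compound 3 (1.00 log units; beyond the scatter), which shows that moving one chlorine on the phenyl ring alone changes the number noticeably. Among the compounds with values here, compound 2 differs from compounds 1 and 3 in two places at once, the core and the phenyl substitution pattern, so no measured step isolates either of them.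

Compound 4, `COc1ccc(OCCCON2C(N)=NC(N)=NC23CCOCC3)cc1`, is not yet measured. Its change from compound 2 is 4-methoxyphenyl in place of 2,4,5-trichlorophenyl on an oxygen on a saturated carbon. Within the data shown here, no measured step covers this exchange. The closest hint comes from compound 3, which on a different core carries a single substituent on the phenyl ring and gives 10 nM. Because compound 2 gives 2750 nM on the shared core, the expectation for compound 4 is a lower number than compound 2, with wide uncertainty: the estimated step is a 4.6-fold lower number from compound 2 to compound 4 (0.66 log units; beyond the scatter). Compound 4 is therefore estimated at 600 nM, within a range from 60 nM to 6000 nM.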

Compound 4, half-maximal inhibitory concentration: 1500 nM
Compound 4: middle estimate off by 2.5-fold (0.40 log units), on the low side; the measured number falls inside the stated range.
By their numbers in this assay, from the lowest: compound 1; then compound 3; then compounds 4 and 2 (each within the scatter of the next).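

In this assay the exchange of 2,4,5-trichlorophenyl for 4-methoxyphenyl on an oxygen on a saturated carbon gives (a 1.8-fold lower number from compound 2 to compound 4 (0.26 log units; within the scatter)), so on the shared core of these two compounds the two aromatic ends cannot be told apart by this read-out. This exchange removes every chlorine and adds a hydrogen-bond acceptor, yet it produces no readable shift, whereas on the core of compound 1 the move of a single chlorine gave (a 10-fold higher number from compound 1 to compound 3 (1.00 log units; beyond the scatter)), which lies beyond the scatter. Nothing measured here accounts for that contrast.

Compounds 1 and 3 differ from compounds 2 and 4 in both the core and the phenyl substitution, so the compounds shown leave open how much of the gap in their numbers belongs to the core alone. Also open, as far as these compounds go, is whether an amine or a carboxylic acid on the phenyl ring, or a longer chain in place of the present saturated chain, would give a readable step on the shared core of compounds 2 and 4.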